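Amide chain extension on compound 1

The source may report more compounds than this note shows. Statements on the series, on what has been measured and on what is new or still open speak of the compounds shown alone.

Measured so far:
compound 1 `CNC(=O)c1cccc(C#Cc2ccccc2Nc2ncnc3ccc(Cl)nc23)c1` gives 4900 nM in an assay on isolated protein for inhibition of MAP kinase-interacting serine/threonine-protein kinase 2 (Homo sapiens), read by HTRF, in the presence of a further agent that is not named here; a higher number here means a weaker inhibitor, a lower number a stronger inhibitor
compound 2 `Cc1c(C(=O)N2CCOCC2)oc2ccc(Nc3ncnc4ccc(Cl)nc34)cc12` gives 1800 nM in this assay
compound 3 `COC(=O)c1oc2ccc(Nc3ncnc4ccc(Cl)nc34)cc2c1C` gives 4800 nM in this assay

Compound 1 stands at the highest of the three numbers in this assay. Its gap to compound 3 lies within the scatter, so the two cannot be ordered; its gap to compound 2 lies beyond the scatter, with compound 2 the lower of the pair.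

Compound 4 `CCCNC(=O)c1cccc(C#Cc2ccccc2Nc2ncnc3ccc(Cl)nc23)c1` differs from compound 1 by ethyl in place of hydrogen on a saturated chain carbon bound to an amide-type nitrogen. Within the data shown here, only one step within the measured set changes a carbonyl substituent: a 2.7-fold higher number from compound 2 to compound 3 (0.43 log units; beyond the scatter). That step swaps the whole group on the carbonyl carbon, from a cyclic amine to methoxy, and sits on compounds whose carbonyl is carried on a different ring from that of compound 1. Among the measured compounds shown here, no measured step lengthens an alkyl chain on an amide-type nitrogen, so the present change has no direct precedent here. Since the swap from compound 2 to compound 3 was only modest, and the present change is smaller in kind, the step from compound 1 to compound 4 is expected to stay within or near the scatter, with no confident direction; as a working guess it is taken as a 1.2-fold lower number from compound 1 to compound 4 (0.09 log units; within the scatter). Compound 4 is therefore estimated at 4000 nM in this assay, with a range from 1500 nM to 11000 nM.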

Compound 4, half-maximal inhibitory concentration: 3900 nM
Compound 4: middle estimate off by 1.0-fold (0.01 log units), on the high side, within the range that was stated.
By their numbers in this assay, from the lowest: compound 2; then compounds 4, 3 and 1 (each within the scatter of the next).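

Lengthening the chain on the amide-type nitrogen, methylcarbamoyl to propylcarbamoyl, gives a 1.3-fold lower number from compound 1 to compound 4 (0.10 log units; within the scatter) in this assay, so compound 1 and compound 4 cannot be ordered. Among these compounds, this is the first measured step that changes only the alkyl chain on this nitrogen, whereas the earlier step on a carbonyl substituent, a 2.7-fold higher number from compound 2 to compound 3 (0.43 log units; beyond the scatter), replaced the whole group on a different scaffold. At this position, an added ethyl with no ring, hydrogen-bond donors or acceptors leaves the reading within the scatter, and the series has no information yet on why, as no supporting data bear on this result.

The compounds shown leave open whether a longer chain, or a chain ending in an amine, a hydroxyl or a carboxylic acid, would move the number beyond the scatter in this assay, since a single step from methyl to propyl cannot define a trend along the chain. They also leave open whether a cyclic amine such as morpholin-4-yl on this carbonyl, or a second alkyl group in place of the amide hydrogen, would change the reading of compound 1 at 4900 nM in either direction.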